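The source may hold more compounds than are shown below. What is called first, only, known or untested is meant among the compounds shown, and "the series" means these compounds.

Compound 2 `Cc1nc(NCC2CCC2)nc(N[C@@H]2C[C@H](CO)[C@@H](O)[C@H]2O)c1-c1nc2ccccc2s1` gives the lowest number of the three measured in an ADME assay on the whole organism (plasma) for pharmacokinetics, with Rattus norvegicus as the target, with a stated time of 6 h, at a dose of 10 mg/kg by the oral route (a lower number here means less compound in the circulation, a higher number more compound in the circulation at the dose given), at 228 ng.h/mL. Compound 3 `Cc1nc(NCc2ccccc2)nc(N[C@@H]2C[C@H](CO)[C@@H](O)[C@H]2O)c1-c1nc2ccccc2s1` gives 1050 ng.h/mL, and compound 1 `Cc1nc(NC(C)C)nc(N[C@@H]2C[C@H](CO)[C@@H](O)[C@H]2O)c1-c1nc2ccccc2s1` gives 8420 ng.h/mL; the measured steps are a 37-fold lower number from compound 1 to compound 2 (1.57 log units; beyond the scatter), an 8.0-fold lower number from compound 1 to compound 3 (0.90 log units; beyond the scatter) and a 4.6-fold higher number from compound 2 to compound 3 (0.66 log units; beyond the scatter). Compound 4 `Cc1nc(NCc2ccccn2)nc(N[C@@H]2C[C@H](CO)[C@@H](O)[C@H]2O)c1-c1nc2ccccc2s1` differs from compound 2 in one place: pyridin-2-yl in place of cyclobutyl on a saturated chain carbon bound to a nitrogen on an aromatic ring. Within the data shown here, the only measured step at this place is a 4.6-fold higher number from compound 2 to compound 3 (0.66 log units; beyond the scatter), a modest step upward. Among the measured compounds shown here, no measured pair sets pyridin-2-yl against phenyl, so that part of the change rests on no data. An upward step of roughly that size is therefore expected, a 3.9-fold higher number from compound 2 to compound 4 (0.60 log units; beyond the scatter). Compound 4 is estimated at 900 ng.h/mL, with a range from 250 ng.h/mL to 3500 ng.h/mL.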

Compound 4, area under the concentration-time curve: 1630 ng.h/mL
Compound 4: middle estimate off by 1.8-fold (0.26 log units), on the low side, within the range that was stated.
By their numbers in this assay, from the lowest: compound 2; then compounds 3 and 4 (each within the scatter of the next); then compound 1.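

In this assay, pyridin-2-yl gives a 7.1-fold higher number from compound 2 to compound 4 (0.85 log units; beyond the scatter), so a second aromatic ring at this place stands clear of cyclobutyl. Against phenyl it gives a 1.6-fold higher number from compound 3 to compound 4 (0.19 log units; within the scatter), a step within the scatter, so the ring nitrogen of pyridin-2-yl makes no readable difference here, and a 5.2-fold lower number from compound 1 to compound 4 (0.71 log units; beyond the scatter) shows that (pyridin-2-yl)methyl, like benzyl, stays under isopropyl on the nitrogen; no measurement bearing on the cause of these steps is at hand.

On these data alone, whether pyridin-3-yl or pyridin-4-yl at this place would match pyridin-2-yl remains open. Also open, as far as these compounds go, is whether a tert-butyl or cyclopropyl group on the nitrogen would reach the number of compound 1.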